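Ring size change on the aniline nitrogen of compound 2

The source may hold more compounds than are shown below. What is called first, only, known or untested is meant among the compounds shown, and "the series" means these compounds.

Measured so far:
Compound 1 `CCCCN(C)c1cc(C(F)(F)F)ccc1CNC(=O)C(C)c1ccc(NS(C)(=O)=O)c(F)c1` — 1.2 nM
Compound 2 `CC(C(=O)NCc1ccc(C(F)(F)F)cc1N1CCCCCCC1)c1ccc(NS(C)(=O)=O)c(F)c1` — 2.8 nM

In an assay on CHO cells for antagonist activity at transient receptor potential cation channel subfamily V member 1 (Homo sapiens), read by FLIPR (a higher number here means a weaker inhibitor, a lower number a stronger inhibitor), compound 2 gives the highest of the two numbers, with compound 1 giving a lower one by a 2.3-fold higher number from compound 1 to compound 2 (0.37 log units; beyond the scatter). Compound 3 `CCC1CCN(c2cc(C(F)(F)F)ccc2CNC(=O)C(C)c2ccc(NS(C)(=O)=O)c(F)c2)CC1` is not yet measured. It differs from compound 2 in a group of 8 heavy atoms (7 carbon, 1 nitrogen; one six-membered non-aromatic ring with 1 hetero atom) in place of a group of 8 heavy atoms (7 carbon, 1 nitrogen; one eight-membered non-aromatic ring with 1 hetero atom), on an aromatic carbon. Going by the values given here, the only measured step at this position is a 2.3-fold higher number from compound 1 to compound 2 (0.37 log units; beyond the scatter), a modest change between two amine substituents, so compound 3 is expected to stay near compound 2, with a step of about a 1.4-fold lower number from compound 2 to compound 3 (0.15 log units; within the scatter) and no change beyond the scatter. For compound 3 the estimate is 2 nM, within the range 0.7 nM to 6 nM.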

Compound 3, inhibition constant: 0.7 nM
Compound 3: middle estimate off by 2.9-fold (0.46 log units), on the high side, and the stated range covers the measured number.
By their numbers in this assay, from the lowest: compounds 3 and 1 (each within the scatter of the next); then compound 2.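

In this assay, 4-ethylpiperidin-1-yl in place of the eight-membered ring gives a 4.0-fold lower number from compound 2 to compound 3 (0.60 log units; beyond the scatter) with the heavy-atom count unchanged, so at this position the arrangement of the atoms matters and not their number alone. Set against butyl(methyl)amino, the same group gives a 1.7-fold lower number from compound 1 to compound 3 (0.23 log units; within the scatter) and thus cannot be told apart from the open-chain amine. Nothing measured here accounts for the difference between the two rings. Still open, going by these compounds, is whether an unsubstituted piperidine, a morpholine or a seven-membered ring would hold this level.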